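Chloro Position on the Triazole Aryl Across Two Cores

This account rests on a few compounds, and the source may have more. Where it says the series, first, only, none or still open, it means among the compounds named here.

Compound 1 `O=c1[nH]cc(S(=O)(=O)Nc2cccc(-c3cn(-c4cccc(Cl)c4)nn3)c2)c(=O)[nH]1` and compound 2 `O=c1[nH]cc(S(=O)(=O)Nc2cccc(-c3cn(-c4ccc(Cl)cc4)nn3)c2)c(=O)[nH]1` share one core, while compound 3 `O=c1[nH]cc(S(=O)(=O)Nc2ccc(-c3cn(-c4cccc(Cl)c4)nn3)cc2)c(=O)[nH]1` and compound 4 `O=c1[nH]cc(S(=O)(=O)Nc2ccc(-c3cn(-c4ccc(Cl)cc4)nn3)cc2)c(=O)[nH]1` share another; the difference between the two cores is not broken down here. In a functional assay on OVCAR-3 cells (Homo sapiens) for antiproliferative activity, read by MTT assay, with a stated time of 24 h (a higher number here means a weaker inhibitor, a lower number a stronger inhibitor), compound 1 gives 3410 nM and compound 2 gives 2040 nM. The change between them, (4-chlorophenyl in place of 3-chlorophenyl on an aromatic nitrogen), made a 1.7-fold lower number from compound 1 to compound 2 (0.22 log units; within the scatter). Compound 3 gives 2750 nM in this assay, a value within the scatter of both compound 1 and compound 2. Compound 4 carries the same change on the other core: 4-chlorophenyl in place of 3-chlorophenyl on an aromatic nitrogen. Because the earlier step of a 1.7-fold lower number from compound 1 to compound 2 (0.22 log units; within the scatter) stayed within the scatter, compound 4 is expected to shift by a similar amount, a 1.5-fold lower number from compound 3 to compound 4 (0.18 log units; within the scatter). The estimated value for compound 4 in this assay is 1800 nM, with a likely range from 900 nM to 3600 nM.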

Compound 4, half-maximal inhibitory concentration: 2160 nM
Estimate against measurement, compound 4: 1.2-fold (0.08 log units) below; the range from low to high includes it.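

In this assay, 4-chlorophenyl in place of 3-chlorophenyl gave a 1.3-fold lower number from compound 3 to compound 4 (0.10 log units; within the scatter), a step as small on this core as on the core of compound 1. The two steps do not differ beyond what repeated measurement would produce, so the change carried from one core to the other without a detectable difference: the same change on two cores in this assay, a 1.7-fold lower number (0.22 log units; within the scatter) from compound 1 to compound 2 and a 1.3-fold lower number (0.10 log units; within the scatter) from compound 3 to compound 4, 1.3-fold (0.12 log units) apart, within the scatter of two such steps. Both steps lie within the scatter, so this does not show a real effect of the chloro position on either core, and it says nothing about cores beyond these two.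

The compounds shown leave open whether a methoxy group, a fluorine or an amine on that phenyl would read differently. As far as these compounds go, it also remains open whether an unsubstituted phenyl would match the chlorophenyl compounds.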